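The source may hold more compounds than are shown below. What is called first, only, known or untested is meant among the compounds shown, and "the series" means these compounds.

Going by the values given here, in an ADME assay on Huh7.5.1 cells (Homo sapiens) for cytotoxicity, read by ATP content, with a stated time of 48 h (a higher number here means that more compound is tolerated, a lower number that less compound is tolerated), compound 3 (`Cc1ccccc1-c1nc(CN2CCC(C(=O)NCCCN3[C@H](C)CCC[C@@H]3C)CC2)c(C)o1`) gives 21300 nM, the highest of the three numbers so far. Compound 1 (`CC[C@@H]1C[C@H](CC)CN(CCCNC(=O)C2CCN(Cc3nc(-c4ccccc4C)oc3C)CC2)C1`) gives 3470 nM and compound 2 (`Cc1ccccc1-c1nc(CN2CCC(C(=O)NCCCN3CC(C)(C)CC(C)(C)C3)CC2)c(C)o1`) gives 4380 nM, and a 1.3-fold higher number from compound 1 to compound 2 (0.10 log units; within the scatter) is within the scatter. Compound 4 (`Cc1ccccc1-c1nc(CN2CCC(C(=O)NCCCN3CC4CCCC(C4)C3)CC2)c(C)o1`) differs from compound 3 at one place: a group of 9 heavy atoms (8 carbon, 1 nitrogen; one six-membered non-aromatic ring of carbon only, one six-membered non-aromatic ring with 1 hetero atom) in place of a group of 8 heavy atoms (7 carbon, 1 nitrogen; one six-membered non-aromatic ring with 1 hetero atom), on a saturated chain carbon, three bonds along the chain from an amide-type nitrogen. Two measured steps swap the group at this same place, a 6.1-fold higher number from compound 1 to compound 3 (0.79 log units; beyond the scatter) and a 4.9-fold higher number from compound 2 to compound 3 (0.69 log units; beyond the scatter), both modest and beyond the scatter. The entering group has more heavy atoms than the group in compound 3 but fewer than those in compound 1 and compound 2, so a smaller step towards a lower number is expected. The expected step is a 2.7-fold lower number from compound 3 to compound 4 (0.43 log units; beyond the scatter). For compound 4, the estimate is 8000 nM, with an expected range from 3500 nM to 18000 nM.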

Compound 4, half-maximal cytotoxic concentration: 10900 nM
Estimate against measurement, compound 4: 1.4-fold (0.13 log units) below; low and high end bracket the measured number.
By their numbers in this assay, from the lowest: compounds 1 and 2 (each within the scatter of the next); then compounds 4 and 3 (each within the scatter of the next).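

In this assay, the two-ring group of compound 4 does not separate from 2,6-dimethylpiperidin-1-yl (a 2.0-fold lower number from compound 3 to compound 4 (0.29 log units; within the scatter)), so adding a second ring at this place does not by itself bring the number down. Going by these compounds alone, that group still gives a higher number than either group of 10 heavy atoms (a 2.5-fold higher number from compound 2 to compound 4 (0.40 log units; beyond the scatter)) (a 3.1-fold higher number from compound 1 to compound 4 (0.50 log units; beyond the scatter)), and no compound here goes against this split by group size. Nothing measured here explains this split. From the compounds shown here alone, whether the number would rise further with a smaller group, such as unsubstituted piperidine or dimethylamino, remains open.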